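Removing both ring substituents from the aryl hydrazone of compound 1

The source may hold more compounds than are shown below. What is called first, only, known or untested is meant among the compounds shown, and "the series" means these compounds.

Among the compounds with values here, compound 1 `Cc1c(C(=O)N/N=C\c2cccc(F)c2O)oc2cccc(O)c12` holds the lowest number of the three measured so far: in a functional assay on PC-3 cells (Homo sapiens) for inhibition (on this read-out lower numbers stand for stronger inhibition and higher numbers for weaker inhibition), compound 1 gives 12700 nM. Compound 3 `Cc1c(C(=O)N/N=C\c2cc([N+](=O)[O-])ccc2O)oc2cccc(O)c12` gives 17100 nM, which sits within the scatter of compound 1, so no order between these two can be claimed. Compound 2 `Cc1c(C(=O)N/N=C\c2cc(O)ccc2O)oc2cccc(O)c12` gives 95500 nM, clearly apart; the step is a 7.5-fold higher number from compound 1 to compound 2 (0.88 log units; beyond the scatter), and the step of a 5.6-fold lower number from compound 2 to compound 3 (0.75 log units; beyond the scatter) recovers most of that.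

Compound 4 `Cc1c(C(=O)N/N=C\c2ccccc2)oc2cccc(O)c12` differs from compound 1 as follows: phenyl in place of 3-fluoro-2-hydroxyphenyl on a carbon with a double bond to nitrogen. Within the data shown here, both measured steps alter the same ring and both are modest and beyond the scatter, showing that this ring is not inert to change; the change to compound 4 strips away the hydroxy and the fluorine at once, which no measured pair covers directly. A modest weakening is expected, less than the step from compound 1 to compound 2, since compound 3 shows that a heavily altered ring can still land near compound 1. The estimated step is a 2.4-fold higher number from compound 1 to compound 4 (0.37 log units; beyond the scatter), and compound 4 is expected to give 30000 nM, within a range from 10000 nM to 100000 nM.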

Compound 4, half-maximal inhibitory concentration: 29200 nM
The estimate for compound 4 lay 1.0-fold (0.01 log units) above the measured number, and the stated range covers the measured number.
By their numbers in this assay, from the lowest: compounds 1, 3 and 4 (each within the scatter of the next, the first and the last beyond it); then compound 2.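

In this assay, within the data shown here, compound 4 gives the first reading for an unsubstituted phenyl at this carbon, and a 2.3-fold higher number from compound 1 to compound 4 (0.36 log units; beyond the scatter) shows that replacing 3-fluoro-2-hydroxyphenyl with phenyl costs only a modest step. The other new step, a 3.3-fold lower number from compound 2 to compound 4 (0.51 log units; beyond the scatter), places phenyl on the opposite side of 2,5-dihydroxyphenyl, so ring substitution does not move the number in one direction: compound 1 lies lower than compound 4, and compound 2 lies higher. No measurement on hand explains either direction.

Compound 4 loses the hydroxy and the fluorine together, so their separate contributions to the step from compound 1 remain unresolved. Also open, on these data alone, is how an amine or a carboxylic acid on this ring, or a cyclohexyl in place of phenyl, would read.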